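The source may report more compounds than this note shows. Statements on the series, on what has been measured and on what is new or still open speak of the compounds shown alone.

Series notes: the shared core is that of compound 1 `COc1cc(NC(C)CCCNC(=O)NC2CCCCC2)c2ncccc2c1`, carried also by compound 2 `COc1cc(NC(C)CCCNC(=O)NCc2ccncc2)c2ncccc2c1` and compound 3 `COc1cc(NC(C)CCCNC(=O)NNC(=O)/C=C/c2ccccc2)c2ncccc2c1`, which differ only in the group beyond the urea. In an ADME assay on L6 cells (Rattus norvegicus) for cytotoxicity, read by resazurin assay, with a stated time of 70 h (a lower number here means a stronger inhibitor, a higher number a weaker inhibitor), compound 1 gives "not determined" (no result reported), and compound 2 gives "not determined" (no result reported); neither carries a number. In this assay compound 3 gives 13900 nM, and this is the only number shown in the set, so compound 3 stands alone: there is no step between measured compounds to lean on, and no ordering of it against compound 1 or compound 2 can be made.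

The next member is compound 4 `COc1cc(NC(C)CCCNC(=O)NNC(=O)/C=C/c2ccc(Cl)cc2)c2ncccc2c1`. Against compound 3 the change is chloro in place of hydrogen on an aromatic carbon; everything else in the molecule is held.

With a single number available, the expectation for compound 4 rests on the value of compound 3 and on the small size of the change. The step from compound 3 to compound 4 is expected to be small, a 1.4-fold lower number from compound 3 to compound 4 (0.14 log units; within the scatter), toward a somewhat lower number but not clearly beyond the scatter of this assay. For compound 4 the estimate in this assay is 10000 nM, with a range from 4000 nM to 25000 nM.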

Compound 4, half-maximal inhibitory concentration: 7300 nM
Beside the measured number, compound 4's estimate is 1.4-fold (0.14 log units) above it; low and high end bracket the measured number.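

Phenyl to 4-chlorophenyl gives the first step between measured compounds in this assay, and it reads a 1.9-fold lower number from compound 3 to compound 4 (0.28 log units; within the scatter). At this aromatic carbon, para to a large group, chloro in place of hydrogen therefore leaves compound 3 and compound 4 within the scatter of each other, so this pair gives no order and shows no effect of the substitution that can be separated from repeat-to-repeat variation. No measured evidence bearing on this result is at hand.

Steps involving compound 1 or compound 2 cannot be read, as neither carries a number, so the cyclohexyl and pyridinylmethyl-type ends of the series cannot be set against the (2-phenylethenyl)carbonyl end in this read-out. Also open, on these data alone, is how this ring position responds to groups other than chloro, such as methoxy, an amine or a carboxylic acid, and whether chloro on another carbon of the ring would give a step beyond the scatter.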